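The compounds below may be only part of what the source reports. "The series", "measured", "known", "first", "only" and "open" are said of these compounds alone.

Three measured compounds share an amide-bearing side chain on a five-membered core. Compound 1 `C/C(=C\c1cc(-c2ccccc2)co1)C(N)=O` and compound 2 `C/C(=C\c1ccc(-c2ccc(C)cc2)o1)C(N)=O` carry an oxygen-containing core, while compound 3 `C/C(=C\c1cc(-c2ccc(C)cc2)cs1)C(N)=O` carries a sulfur-containing core. In a functional assay on HeLa cells (Homo sapiens) for cytotoxicity, read by CCK-8 assay, with a stated time of 24 h (a lower number here means a stronger inhibitor, a higher number a weaker inhibitor), compound 1 gives 3280 nM. In this assay compound 2 gives 4590 nM; these two values lie within the scatter of each other. Compound 3 reaches only a limit of this assay, recorded as > 50000 nM, so no number stands for it, as shown by the limit of > 50000 nM in this assay, at which 1 of the 3 values shown sits. Compound 4 `C=Cc1ccc(-c2csc(/C=C(\C)C(N)=O)c2)cc1` has not been measured; it differs from compound 3 by a vinyl in place of methyl on an aromatic carbon, namely (vinyl in place of methyl on an aromatic carbon). Because compound 3 sits at a limit, shown by the limit of > 50000 nM in this assay, at which 1 of the 3 values shown sits, no measured step from a methyl to a vinyl exists here to lean on, and a change of this kind and size gives no ground to expect a move beyond the scatter. Compound 4 is therefore expected to stay near that limit, with an estimated step that the limit leaves unreadable from compound 3 to compound 4. Compound 4 is estimated at 60000 nM, within a range from 20000 nM to 200000 nM.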

Compound 4, half-maximal inhibitory concentration: > 50000 nM
Compound 4: no number, only a limit (the forecaster's own chance of this, stated with the estimate: 70%); the middle value does not contradict the limit.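

Compound 3 and compound 4 both sit at a limit of this assay, so the step between them cannot be read: the limit of > 50000 nM in this assay, at which 2 of the 4 values shown sit.

The compounds shown leave open whether vinyl in place of methyl changes the activity at all, and how strong either compound truly is.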